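Aryl piperazine variation in the series: compound 3 to compound 4

The source may report more compounds than this note shows. Statements on the series, on what has been measured and on what is new or still open speak of the compounds shown alone.

Three compounds share a core and differ only in the aryl group on the amine nitrogen in the ring. In an assay on HEK293 cells for inhibition of Voltage-dependent T-type calcium channel subunit alpha-1G (Homo sapiens), read by fluorescence, tested at 10 uM (on this read-out higher numbers stand for more inhibition at the one concentration tested (going by the name of the read-out) and lower numbers for less inhibition), compound 1 `CCCc1nc(-c2ccccc2)c(CNCCCN2CCN(c3ccc(OC)cc3)CC2)o1` gives 42.1%, compound 2 `CCCc1nc(-c2ccccc2)c(CNCCCN2CCN(c3ccccc3C(F)(F)F)CC2)o1` gives 45%, and compound 3 `CCCc1nc(-c2ccccc2)c(CNCCCN2CCN(c3cccc(C)c3C)CC2)o1` gives 55.2%, the highest of the three, with steps of a number 13.1 percentage points higher from compound 1 to compound 3 (beyond the scatter) and a number 10.2 percentage points higher from compound 2 to compound 3 (beyond the scatter), while a number 2.9 percentage points higher from compound 1 to compound 2 (within the scatter). Compound 4 `CCCc1nc(-c2ccccc2)c(CNCCCN2CCN(c3ccccc3C)CC2)o1` carries the change (hydrogen in place of methyl on an aromatic carbon). Going by the values given here, no measured step removes a methyl from this ring, so the two steps into compound 3 give only loose guidance; a small loss is expected, likely not beyond the scatter, with a number 7.2 percentage points lower from compound 3 to compound 4 (within the scatter). Compound 4 is therefore estimated at 48%, between 35% and 60%.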

Compound 4, a percentage reported as inhibition, at one concentration (the size of the read-out at that concentration, not a potency): 54.5%
Compound 4: middle estimate off by 6.5 percentage points, on the low side; the range from low to high includes it.
By their numbers in this assay, from the lowest: compounds 1, 2, 4 and 3 (each within the scatter of the next, the first and the last beyond it).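

In this assay a single methyl on this aromatic ring is enough to keep the read-out level with 2,3-dimethylphenyl, as hydrogen in place of methyl gives a number 0.7 percentage points lower from compound 3 to compound 4 (within the scatter) here. Methyl in place of trifluoromethyl gives a number 9.5 percentage points higher from compound 2 to compound 4 (within the scatter) and so shows no clear separation, while 2-methylphenyl in place of 4-methoxyphenyl gives a number 12.4 percentage points higher from compound 1 to compound 4 (beyond the scatter) and so joins 2,3-dimethylphenyl in standing clear of 4-methoxyphenyl. Nothing at hand accounts for these steps. Open, going by these compounds, is whether chlorine or an ethyl group could stand in place of the remaining methyl, and what a plain phenyl would give.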